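The source may report more compounds than this note shows. Statements on the series, on what has been measured and on what is new or still open speak of the compounds shown alone.

Measured compounds:
- compound 1 `CNC(=O)c1cc(Oc2ccc(/C=C/C(=O)c3ccc(C)cc3)cc2)ccn1`; a functional assay on PC-3 cells (Homo sapiens) for cytotoxicity, read by MTT assay, with a stated time of 72 h; a higher number here means a weaker inhibitor, a lower number a stronger inhibitor: "not determined" (no result reported)
- compound 2 `CNC(=O)c1cc(Oc2ccc(C(=O)/C=C/c3ccc(F)cc3)cc2)ccn1`; this assay: 6140 nM

Compound 1 stands without a number in this assay: no result was reported for it, so it gives no anchor of its own. The only measured point in the series is compound 2, which in this assay gives 6140 nM, a weak inhibitor on this scale. Compound 2 shares the core with compound 1 but carries the carbonyl and the alkene in the opposite sense and a fluoro on the outer ring, so its value can only serve as a rough guide to where compounds of this shape tend to fall.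

Compound 3 `CNC(=O)c1cc(Oc2ccc(/C=C/C(=O)c3ccc(Br)cc3)cc2)ccn1` differs from compound 1 in one place: bromo in place of methyl on an aromatic carbon. Going by the values given here, no pair of measured compounds shows what this change does in this assay. Without a number for compound 1, no direction can be drawn; a step of this kind is expected to stay within the scatter, with no clear direction.

Compound 3 is expected to come out near 6000 nM in this assay, within a range of 1500 nM to 25000 nM, an estimate resting on compound 2 and its 6140 nM as the sole measured reference.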

Compound 3, half-maximal inhibitory concentration: 3560 nM
Compound 3: the middle estimate sits 1.7-fold (0.23 log units) above what was measured, within the range that was stated.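

In this assay, going by these compounds alone, compound 3 gives 3560 nM and compound 1 gives "not determined" (no result reported) so no step between compound 1 and compound 3 can be read. The compounds shown leave open what the change from 4-methylphenyl to 4-bromophenyl does to the value. No measured evidence bears on this result.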